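From difluorophenyl to methoxyphenyl: a small step expected

A few compounds are considered here, and "the series" means these few. Any claim that something is new, unique, unknown or untested is made for them only; others in the source may bear on it.

In a functional assay on HCT-116 cells (Homo sapiens) for antiproliferative activity, with a stated time of 72 h (on this read-out higher numbers stand for weaker inhibition and lower numbers for stronger inhibition), compound 1 `CCCCC#Cc1cc([C@@H]2O[C@H](CO)[C@@H](O)[C@H]2O)n2ncnc(N)c12` gives 2900 nM with a hex-1-yn-1-yl group on the shared core. Compound 2 `Nc1ncnn2c([C@@H]3O[C@H](CO)[C@@H](O)[C@H]3O)cc(-c3ccccc3)c12` gives 82600 nM with phenyl in that place, and compound 3 `Nc1ncnn2c([C@@H]3O[C@H](CO)[C@@H](O)[C@H]3O)cc(-c3ccc(F)cc3F)c12` gives 59500 nM with 2,4-difluorophenyl there. Compound 3 therefore sits level with compound 2 and well apart from compound 1, the compound with the clearly stronger inhibition in this set.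

Compound 4 `COc1ccc(-c2cc([C@@H]3O[C@H](CO)[C@@H](O)[C@H]3O)n3ncnc(N)c23)cc1` has 4-methoxyphenyl in place of 2,4-difluorophenyl on the same aromatic carbon: 4-methoxyphenyl in place of 2,4-difluorophenyl on an aromatic carbon. The closest guide is a 1.4-fold lower number from compound 2 to compound 3 (0.14 log units; within the scatter), a swap between two substituted or plain phenyl groups that stayed within the scatter. The large steps, a 28-fold higher number from compound 1 to compound 2 (1.45 log units; beyond the scatter) and a 21-fold higher number from compound 1 to compound 3 (1.31 log units; beyond the scatter), both replace the hex-1-yn-1-yl group, so they bear less directly, since compound 4 keeps a six-membered aromatic ring of carbon only in that place. Going by the values given here, no compound with a methoxy group has been measured yet, which keeps the range wide.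

The expected change is a 1.2-fold lower number from compound 3 to compound 4 (0.08 log units; within the scatter), which would be no step beyond the scatter. For compound 4 the estimated value is 50000 nM, with an expected range from 18000 nM to 110000 nM in this test.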

Compound 4, half-maximal inhibitory concentration: 47100 nM
Beside the measured number, compound 4's estimate is 1.1-fold (0.03 log units) above it, within the range that was stated.
By their numbers in this assay, from the lowest: compound 1; then compounds 4, 3 and 2 (each within the scatter of the next).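

In this assay, 4-methoxyphenyl brings a hydrogen-bond acceptor and an oxygen atom to this aromatic carbon, yet replacing 2,4-difluorophenyl gives a 1.3-fold lower number from compound 3 to compound 4 (0.10 log units; within the scatter), and methoxy in place of hydrogen on the phenyl ring gives a 1.8-fold lower number from compound 2 to compound 4 (0.24 log units; within the scatter), so neither change can be told apart from repeat-measurement scatter. Phenyl, 2,4-difluorophenyl and 4-methoxyphenyl therefore form a group of three compounds that this read-out does not separate, while the hex-1-yn-1-yl compound stays clearly apart from the newest member, with a 16-fold higher number from compound 1 to compound 4 (1.21 log units; beyond the scatter). The information available gives no reason for either the closeness of the three ring-bearing compounds or the gap to the chain-bearing one.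

The compounds shown leave open whether the stronger inhibition of compound 1 depends on the triple bond or on the length of the chain, a question that a saturated hexyl chain or a shorter alkyne such as prop-1-yn-1-yl could address. They also leave open whether an amine or a carboxylic acid on the phenyl ring would move the number where methoxy and fluorine do not.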